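Replacing Heptyl with Cyclopentyl on a Shared Core

The compounds below may be only part of what the source reports. "The series", "measured", "known", "first", "only" and "open" are said of these compounds alone.

In a functional assay on UMUC3 cells (Homo sapiens) for antiproliferative activity, read by MTT assay, with a stated time of 72 h (a higher number here means a weaker inhibitor, a lower number a stronger inhibitor), compound 1 (`CC(C)NC(=N)NC(=N)Nc1ccc(F)c(F)c1`) gives 25000 nM. Within the data shown here, compound 2 (`CCCCCCCNC(=N)NC(=N)Nc1ccc(F)c(F)c1`) gives 2100 nM, the lower of the two numbers measured so far. Among the measured compounds shown here, only one measured step bears on what follows: a 12-fold lower number from compound 1 to compound 2 (1.08 log units; beyond the scatter), with heptyl in place of isopropyl on an amine nitrogen. That single large step is thin evidence, and it cannot separate the effect of chain length from that of chain shape.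

Compound 3 (`N=C(NC(=N)NC1CCCC1)Nc1ccc(F)c(F)c1`) has not yet been measured in this assay. It differs from compound 2 by cyclopentyl in place of heptyl on an amine nitrogen. This change removes the heptyl group that compound 2 alone carries, so part of the earlier gain is expected to be lost, given the measured step of a 12-fold lower number from compound 1 to compound 2 (1.08 log units; beyond the scatter). The data do not show how a ring behaves here, so the expectation stays broad. The estimated change is a 5.2-fold higher number from compound 2 to compound 3 (0.72 log units; beyond the scatter), towards a higher number. Compound 3 is expected at 11000 nM, with an estimated range from 4000 nM to 30000 nM.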

Compound 3, half-maximal inhibitory concentration: 7200 nM
Compound 3: middle estimate off by 1.5-fold (0.18 log units), on the high side, within the range that was stated.
By their numbers in this assay, from the lowest: compound 2; then compound 3; then compound 1.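

In this assay the step of a 3.4-fold higher number from compound 2 to compound 3 (0.54 log units; beyond the scatter) shows that cyclopentyl on this amine nitrogen does not match heptyl, while the step of a 3.5-fold lower number from compound 1 to compound 3 (0.54 log units; beyond the scatter) shows that it still improves on isopropyl. The two steps are of similar size and both lie beyond the scatter, which places the ring-bearing compound 3 between the two open-chain compounds, with compound 2 lowest and compound 1 highest. Among these compounds, this is the first sign that a ring can stand at this position and keep part of the gain seen with heptyl, although the loss of the longer chain and the arrival of the ring come together in a single change.

The compounds shown leave open whether a straight pentyl chain would fall nearer compound 2 or compound 3, and so whether chain length or the ring accounts for the difference from heptyl. They also leave open whether a cyclohexyl ring or a chain longer than heptyl would give a still lower number. Nothing given here offers a measured explanation for these differences.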